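Hydrogen in place of methoxy on the shared core

The compounds below may be only part of what the source reports. "The series", "measured", "known", "first", "only" and "open" are said of these compounds alone.

Compound 1 `O=C1C(=O)N(CCCCn2cc(COc3cc(=O)oc4ccccc34)nn2)c2ccc([N+](=O)[O-])cc21` gives 53% in a functional assay on HCT-116 cells (Homo sapiens) for inhibition, read by sulforhodamine B assay, with a stated time of 48 h, tested at 50 uM; a higher number here means more inhibition of growth at the concentration tested, a lower number less inhibition of growth.
Compound 2 `COc1ccc2c(c1)C(=O)C(=O)N2CCCCn1cc(COc2cc(=O)oc3ccccc23)nn1` gives 48% in this assay.

Of the compounds shown here, two have been measured so far in this assay. Compound 2 holds the lower of the two numbers, but its nearest neighbour, compound 1, sits within the scatter of it, so the two values cannot be put in order. Among the measured compounds shown here, the only step between them, a number 5 percentage points lower from compound 1 to compound 2 (within the scatter), shows that exchanging the nitro group of compound 1 for methoxy on the aromatic carbon did not move the read-out beyond the scatter.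

Compound 3 `O=C1C(=O)N(CCCCn2cc(COc3cc(=O)oc4ccccc34)nn2)c2ccccc21` is the next member and has not yet been measured. Relative to compound 2 the change is hydrogen in place of methoxy on an aromatic carbon. For the measured compounds named here, the single measured step bears on it only loosely: it concerns the same aromatic carbon, and it was within the scatter. No step beyond the scatter is therefore expected in this assay for this exchange either, in either direction.

The estimate for compound 3 is 49%, with a range from 35% to 63%, which amounts to an expected step of a number 1 percentage points higher from compound 2 to compound 3 (within the scatter).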

Compound 3, percent growth inhibition at one concentration: 72%
Beside the measured number, compound 3's estimate is 23 percentage points below it, outside the stated range (above it).
By their numbers in this assay, from the lowest: compounds 2 and 1 (each within the scatter of the next); then compound 3.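

In this assay there is a number 24 percentage points higher from compound 2 to compound 3 (beyond the scatter) and a number 19 percentage points higher from compound 1 to compound 3 (beyond the scatter) when hydrogen takes the place of either group on this aromatic carbon, so this position is not indifferent to substitution, as the comparison of nitro with methoxy alone had suggested. Among these three compounds the division lies between hydrogen on one side and the two substituents on the other, while nitro and methoxy remain within the scatter of each other and cannot be put in order. No information at hand explains why hydrogen stands apart from both groups.

On these data alone, with only two substituents set against hydrogen, it remains open whether any group at this carbon gives the lower level or whether a smaller one, such as fluorine, or a different one, such as an amine or a carboxylic acid, would stay nearer to hydrogen. The read-out is also taken at a single concentration, which leaves open whether the separation would hold across a range of concentrations, and whether it would persist on a core with a longer chain.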